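A few compounds are considered here, and "the series" means these few. Any claim that something is new, unique, unknown or untested is made for them only; others in the source may bear on it.

Measured so far:
Compound 1 `CCn1sc(Cl)cc1=O`: 3000 nM
Compound 2 `COC(=O)CCn1sc(Cl)cc1=O`: 1800 nM
Compound 3 `CCn1c(=O)c(C)c(Cl)[s+]1[O-]`: > 10000 nM, a limit of the assay

All three were tested in an assay on isolated protein for inhibition of histone acetyltransferase KAT2B (Homo sapiens), read by fluorescence, with a stated time of 15 min; on this read-out higher numbers stand for weaker inhibition and lower numbers for stronger inhibition. Compound 1 and compound 2 share one core, and compound 2 carries the change (methoxycarbonyl in place of hydrogen on a saturated chain carbon, two bonds along the chain from an aromatic nitrogen). The step of a 1.7-fold lower number from compound 1 to compound 2 (0.22 log units; within the scatter) is small. Compound 3 has a different core; the difference between the two cores is not broken down here. For compound 3 this assay gives only a limit, (the limit of > 10000 nM in this assay, at which 1 of the 3 values shown sits), and no number.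

Compound 4 `COC(=O)CCn1c(=O)c(C)c(Cl)[s+]1[O-]` has not yet been measured. It stands to compound 3 as compound 2 stands to compound 1: the change methoxycarbonyl in place of hydrogen on a saturated chain carbon, two bonds along the chain from an aromatic nitrogen is the same change, at the same place in words. Because the earlier step of a 1.7-fold lower number from compound 1 to compound 2 (0.22 log units; within the scatter) stayed within the scatter, the same change on compound 3 is expected to move little, so compound 4 is estimated to give 10000 nM in this assay, between 4000 nM and 30000 nM. The expected step is a number no higher from compound 3 to compound 4 (the limit leaves the size open), and since compound 3 sits at a limit, compound 4 is expected most likely to return only a limit as well.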

Compound 4, half-maximal inhibitory concentration: > 10000 nM
Compound 4: no number, only a limit; the forecaster's own chance of this, stated with the estimate: 70%; the middle value lies on the limit itself.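

Compound 3 and compound 4 both stop at a limit of this assay and give no number, so no step between them can be read: the limit of > 10000 nM in this assay, at which 2 of the 4 values shown sit.

The compounds shown leave open whether methoxycarbonyl in place of hydrogen shifts inhibition at all on the core of compound 3, and how any such shift would compare with the same change on the core of compound 1.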